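Series notes: aryl hydrazone variation on a shared core

The compounds below may be only part of what the source reports. "The series", "measured", "known", "first", "only" and "open" are said of these compounds alone.

Compound 3 `C(=N/Nc1nc2ccccc2nc1Cc1ccccc1)\c1ccccc1` gives 320000 nM in an assay on isolated protein for inhibition of Amine oxidase [flavin-containing] B (Homo sapiens), read by spectrophotometry (on this read-out higher numbers stand for weaker inhibition and lower numbers for stronger inhibition), the lowest of the three numbers shown. Compound 1 `COc1ccccc1/C=N/Nc1nc2ccccc2nc1Cc1ccccc1` gives 790000 nM in this assay, and compound 2 `COc1ccc(/C=N/Nc2nc3ccccc3nc2Cc2ccccc2)cc1OC` gives 460000 nM. The step of a 2.5-fold lower number from compound 1 to compound 3 (0.39 log units; beyond the scatter) is modest but beyond the scatter; the step of a 1.4-fold lower number from compound 2 to compound 3 (0.16 log units; within the scatter) stays within it, as does a 1.7-fold lower number from compound 1 to compound 2 (0.23 log units; within the scatter).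

Compound 4 `Clc1ccc(/C=N/Nc2nc3ccccc3nc2Cc2ccccc2)cc1` differs from compound 3 by chloro in place of hydrogen on an aromatic carbon. Going by the values given here, no measured step places a chloro group on this ring; the two steps that touch the ring, a 2.5-fold lower number from compound 1 to compound 3 (0.39 log units; beyond the scatter) and a 1.4-fold lower number from compound 2 to compound 3 (0.16 log units; within the scatter), both concern methoxy groups and were at most modest. On that basis the step to compound 4 is expected to be small in either direction, most likely within the scatter, and the estimate is a 1.3-fold lower number from compound 3 to compound 4 (0.11 log units; within the scatter).

For compound 4 the expected value in this assay is 250000 nM, with a range from 90000 nM to 700000 nM.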

Compound 4, half-maximal inhibitory concentration: 84000 nM
For compound 4 the middle estimate is 3.0-fold (0.47 log units) above the measured one; measured number outside the range, below it.
By their numbers in this assay, from the lowest: compound 4; then compounds 3, 2 and 1 (each within the scatter of the next, the first and the last beyond it).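

Chloro in place of hydrogen on this aromatic carbon, para to a large group, gives a 3.8-fold lower number from compound 3 to compound 4 (0.58 log units; beyond the scatter) in this assay, a larger step than any among the earlier compounds, where the changes on this ring concerned only methoxy groups. The 4-chlorophenyl group also separates from both methoxy-bearing rings, with a 5.5-fold lower number from compound 2 to compound 4 (0.74 log units; beyond the scatter) and a 9.4-fold lower number from compound 1 to compound 4 (0.97 log units; beyond the scatter) as the two steps, so compound 4 is the strongest inhibitor of the four shown and a group on this ring can lower the number beyond the scatter. Nothing available here explains this step.

The compounds shown leave open whether the step belongs to chloro in particular or to other groups on this carbon, such as bromo, methyl or an amine. Also open, as far as these compounds go, is whether chloro on another carbon of this ring gives a similar step.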